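Benzofuranyl in place of fluorophenyl on a pyridone scaffold

This account rests on a few compounds, and the source may have more. Where it says the series, first, only, none or still open, it means among the compounds named here.

Measured compounds:
compound 1 `CNC(=O)c1cc(C(=O)NCCOC)cn(Cc2ccccc2)c1=O` gives 2.7
compound 2 `CNC(=O)c1cc(C(=O)NC2CC2)cn([C@H](C)c2ccccc2)c1=O` gives 3.4
compound 3 `CNC(=O)c1cc(C(=O)NC2CC2)cn(Cc2ccc(F)cc2)c1=O` gives 3.2

Three compounds sharing one core have been characterised in a physicochemical assay for lipophilicity, at pH 7.4; on this read-out lower numbers stand for lower lipophilicity and higher numbers for higher lipophilicity. Compound 3 stands second highest of the three numbers; its nearest neighbour is compound 2, with a number 0.20 log units lower from compound 2 to compound 3 (within the scatter), while compound 1 lies furthest away, its value being lower than that of compound 3 by an amount beyond the scatter.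

The next compound, compound 4 `CNC(=O)c1cc(C(=O)NC2CC2)cn(Cc2cccc3occc23)c1=O`, is yet to be measured. Compared with compound 3 the change is 1-benzofuran-4-yl in place of 4-fluorophenyl on a saturated chain carbon bound to an aromatic nitrogen. For the measured compounds named here, the only measured step that touches the same position, the aromatic nitrogen substituent, is a number 0.20 log units lower from compound 2 to compound 3 (within the scatter), a change of a different kind that stayed within the scatter. Going by the values given here, no measured step exchanges a fluorophenyl for a bicyclic aromatic group, so the expectation rests on the heavy-atom count of the entering group alone. A modest rise in this assay is therefore expected, giving a number 0.40 log units higher from compound 3 to compound 4 (beyond the scatter). Compound 4 is estimated at 3.6, with a range from 3.2 to 4.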

Compound 4, distribution coefficient: 3.4
Compound 4: middle estimate off by 0.20 log units, on the high side; low and high end bracket the measured number.
By their numbers in this assay, from the lowest: compound 1; then compounds 3, 2 and 4 (each within the scatter of the next).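

In this assay, placing 1-benzofuran-4-yl where 4-fluorophenyl stood, on a saturated chain carbon bound to an aromatic nitrogen, gives a number 0.20 log units higher from compound 3 to compound 4 (within the scatter), so adding a five-membered aromatic ring with one hetero atom, and losing the fluorine, leaves no change that can be told from the scatter. The earlier step at this position, a number 0.20 log units lower from compound 2 to compound 3 (within the scatter), exchanged 1-phenylethyl for 4-fluorobenzyl and also stayed within the scatter, so both measured exchanges here, the first to involve a bicyclic aromatic group being the new one, fail to separate the compounds on this read-out. Nothing available explains why the larger group leaves the number within the scatter of compound 3.

From the compounds shown here alone, whether a phenyl ring carrying an amine or a carboxylic acid, or a longer chain in place of the aromatic group, would move the number beyond the scatter at this position remains open. Compound 1 differs from compound 3 in more than one place, so the part played by its 2-methoxyethyl amide on its own also remains unresolved.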